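Swapping a Hydroxypropyl Chain for a Triazole Ring

The source may hold more compounds than are shown below. What is called first, only, known or untested is meant among the compounds shown, and "the series" means these compounds.

Compound 1 `Cc1c(Cc2ccccc2)c(=O)oc2cc(OCC(O)CNc3cc([N+](=O)[O-])ccc3O)ccc12` in an ADME assay on A549 cells (Homo sapiens) for cytotoxicity, read by CellTiter-Glo (a lower number here means that less compound is tolerated, a higher number that more compound is tolerated), gives > 100000 nM, which is a limit of the assay and not a number.
Compound 2 `Cc1c(Cc2ccccc2)c(=O)oc2cc(OCC(O)CNc3ccc(Br)cc3)ccc12` gives > 100000 nM in this assay, again a limit.
Compound 3 `Cc1c(Cc2ccccc2)c(=O)oc2cc(OCC(O)CNCCCO)ccc12` gives 53400 nM in this assay.

For the measured compounds named here, compound 3 thus carries the only real number among the three measured compounds; the other two sit at the limit described by the limit of > 100000 nM in this assay, at which 2 of the 3 values shown sit. The step from compound 1 to compound 3 is an at least 1.8-fold lower number from compound 1 to compound 3 (0.27 log units; that floor lies within the scatter), and the step from compound 2 to compound 3 is an at least 1.8-fold lower number from compound 2 to compound 3 (0.27 log units; that floor lies within the scatter). Between compound 1 and compound 2 the step is a step that the two limits leave unreadable from compound 1 to compound 2.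

Compound 4 `Cc1c(Cc2ccccc2)c(=O)oc2cc(OCC(O)CNn3ccnn3)ccc12` differs from compound 3 as follows: 1H-1,2,3-triazol-1-yl in place of 3-hydroxypropyl on an amine nitrogen. Going by the values given here, no measured step covers this exact change; the steps that exist swap the amine substituent between aryl groups and the 3-hydroxypropyl chain, and none of them reaches beyond the scatter. On that basis the step from compound 3 to compound 4 in this assay is expected to be a 1.1-fold higher number from compound 3 to compound 4 (0.05 log units; within the scatter), with no change beyond the scatter. Compound 4 is therefore estimated at 60000 nM, within a range from 20000 nM to 150000 nM.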

Compound 4, half-maximal cytotoxic concentration: > 100000 nM
Compound 4 gave a limit, no number; the forecaster's own chance of this, stated with the estimate: 40%; at least 1.6-fold (0.22 log units) between middle value and limit.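

For the compounds shown here, until now, the only groups on this amine nitrogen were two aryl groups and the 3-hydroxypropyl chain. Going by these compounds alone, compound 4 adds a five-membered aromatic ring with 3 hetero atoms, and in this assay the change from the chain to 1H-1,2,3-triazol-1-yl gives an at least 1.8-fold higher number from compound 3 to compound 4 (0.27 log units; that floor lies within the scatter), so it shows no sign of less compound being tolerated, although the size of the step stays unknown. The steps from compound 1 and compound 2 to compound 4 cannot be read, as each joins two limits, and compound 3 remains the only compound with a real number: the limit of > 100000 nM in this assay, at which 3 of the 4 values shown sit.

From the compounds shown here alone, how far apart compound 1, compound 2 and compound 4 really lie stays open, as a shared limit hides any difference among them. Also open, going by these compounds, is how the number of compound 3 would respond to a longer chain ending in a hydroxyl, or to a chain of the same length ending in an amine or a carboxylic acid, and whether the isomeric 1H-1,2,4-triazol-1-yl ring would match the 1H-1,2,3-triazol-1-yl ring of compound 4.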